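The source may report more compounds than this note shows. Statements on the series, on what has been measured and on what is new or still open speak of the compounds shown alone.

Two compounds carry results so far. For the measured compounds named here, in a functional assay on NCI-H460 cells (Homo sapiens) for inhibition (a higher number here means a weaker inhibitor of growth, a lower number a stronger inhibitor of growth), compound 1 (`Nc1ccc(-c2nc3ccc(F)cc3s2)cc1Cl`) gives 100 nM and is the only true reading. Compound 2 (`Cc1cc(-c2nc3cc(F)c(F)cc3s2)ccc1N`) stands at > 100000 nM in this assay and this value is a limit of the assay, not a number.

Going by the values given here, compound 3 (`Cc1cc(-c2nc3ccc(F)cc3s2)ccc1N`) comes from compound 2 by hydrogen in place of fluoro on an aromatic carbon and no measured pair isolates this change. Compound 1 at 100 nM holds a single fluoro group on the core as compound 3 does, though the two differ elsewhere. A move toward stronger growth inhibition, well beyond the scatter, is therefore expected. The expected size is an at least 660-fold lower number from compound 2 to compound 3 (2.82 log units; beyond the scatter) and remains rough. For compound 3 the estimate is 150 nM, with an expected range of 15 nM to 3000 nM in this assay as the working figure.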

Compound 3, concentration for 50% growth inhibition: 100 nM
Beside the measured number, compound 3's estimate is 1.5-fold (0.18 log units) above it; the measured number falls inside the stated range.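

In this assay, the fluoro group ortho to a fluoro group on the fused core is what separates a compound at the assay's limit from a compound with a true reading: hydrogen in its place gives an at least 1000-fold lower number from compound 2 to compound 3 (3.00 log units; beyond the scatter). The substituent on the aniline ring matters far less in the pair at hand, as methyl in place of chloro on an aromatic carbon gives no change at the digits printed from compound 1 to compound 3 (within the scatter). Compound 2 holds a limit and not a number, so the first step is a lower bound on the change: the limit of > 100000 nM in this assay, at which 1 of the 3 values shown sits.

The compounds shown hold the fluoro-to-hydrogen change in a single pair, so it remains open whether the large step would recur with chloro in place of methyl. A methoxy group or a nitrile at the same aromatic carbon would show whether such a step is peculiar to fluoro.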